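Swapping 4-chlorophenyl for 3-hydroxyphenyl on a shared core

The source may report more compounds than this note shows. Statements on the series, on what has been measured and on what is new or still open speak of the compounds shown alone.

For the measured compounds named here, only two compounds built on this kind of core have measured numbers so far. In a functional assay on HT-1080 cells (Homo sapiens) for cytotoxicity, read by MTT assay, with a stated time of 72 h (on this read-out higher numbers stand for weaker inhibition and lower numbers for stronger inhibition), compound 1 (`COc1cc(/C=C2\CCC/C(=C\c3cccc(OC)c3OC)C2=O)cc(OC)c1`) gives 4500 nM and compound 2 (`COc1ccc(/C=C2\CCC/C(=C\c3ccc(Cl)cc3)C2=O)cc1OC`) gives 4800 nM as its result. These two values lie within the usual scatter of repeated measurements, so compound 2 stands level with compound 1 and neither can be ranked ahead.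

Compound 3 (`COc1ccc(/C=C2\CCC/C(=C\c3cccc(O)c3)C2=O)cc1OC`) has not been measured yet. It differs from compound 2 in one place, with 3-hydroxyphenyl in place of 4-chlorophenyl on a double-bonded chain carbon bound to a double-bonded ring carbon.

Going by the values given here, no measured pair shows what a single change of this kind does. Compound 1 at 4500 nM and compound 2 at 4800 nM carry different groups yet sit together, so no step beyond the scatter is expected in this assay and no firm direction can be claimed. The estimated 1.3-fold lower number from compound 2 to compound 3 (0.10 log units; within the scatter) is therefore small. Compound 3 is estimated at 3800 nM with 1400 nM to 10000 nM as its expected range.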

Compound 3, half-maximal inhibitory concentration: 1700 nM
For compound 3 the middle estimate is 2.2-fold (0.35 log units) above the measured one; the measured number falls inside the stated range.
By their numbers in this assay, from the lowest: compound 3; then compounds 1 and 2 (each within the scatter of the next).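

For the compounds shown here, this is the first single change whose effect can be read in this assay, and a 2.8-fold lower number from compound 2 to compound 3 (0.45 log units; beyond the scatter) is a modest step. It shows that the group on a double-bonded chain carbon bound to a double-bonded ring carbon can shift the result, something compounds 1 and 2 could not show, as they differ in more than one place and their numbers lie within the scatter of each other. In this one step 4-chlorophenyl gives way to 3-hydroxyphenyl, and the atom on the ring and its place both alter. No measurement at hand explains the step or separates those two parts.

The compounds shown leave open whether the hydroxyl or its place on the ring matters more, a question that 4-hydroxyphenyl and 3-chlorophenyl at this same position could help to settle. They also leave open whether a hydroxyl is needed at all, or whether another group on the ring, such as an amine or a carboxylic acid, would give a similar number or a clearly different one.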